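Working notes: selenium to cyanosulfanyl on the shared core

The compounds below may be only part of what the source reports. "The series", "measured", "known", "first", "only" and "open" are said of these compounds alone.

Measured so far:
compound 1 `O=C1c2ccccc2C(=O)N1CS` gives 74700 nM
compound 2 `O=C1c2ccccc2C(=O)N1C[SeH]` gives 6400 nM

For the measured compounds named here, in a functional assay on PC-3 cells (Homo sapiens) for cytotoxicity, read by MTT assay, with a stated time of 72 h (on this read-out higher numbers stand for weaker inhibition of growth and lower numbers for stronger inhibition of growth), compound 2 holds the lowest of the two numbers; the only neighbour is compound 1, and the gap between them is a 12-fold lower number from compound 1 to compound 2 (1.07 log units; beyond the scatter), a large step well beyond the scatter.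

Compound 3 `N#CSCN1C(=O)c2ccccc2C1=O` is not yet measured. The change from compound 2 is a group of 3 heavy atoms (1 carbon, 1 nitrogen, 1 sulfur; no ring) in place of one selenium atom, on a saturated chain carbon bound to an amide-type nitrogen in a ring. Going by the values given here, the one measured step that touches this site is a 12-fold lower number from compound 1 to compound 2 (1.07 log units; beyond the scatter): selenium in place of sulfur at the same position lowered the number strongly. Compound 3 brings sulfur back to that carbon, now as part of a cyanosulfanyl group, so the measured step argues for a move in the opposite direction, toward higher numbers. Among the compounds with values here, no measured pair shows what the nitrile on that sulfur does, so the size is taken as somewhat smaller than the measured step, with a wide range.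

The expected step is a 4.7-fold higher number from compound 2 to compound 3 (0.67 log units; beyond the scatter). Compound 3 is therefore estimated at 30000 nM, with a likely range from 8000 nM to 120000 nM.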

Compound 3, concentration for 50% growth inhibition: > 100000 nM
Compound 3 gave a limit, no number; the forecaster's own chance of this, stated with the estimate: 10%; middle value at least 3.3-fold (0.52 log units) away from the limit.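

In this assay, compound 3 gives a limit of the assay and not a number: the limit of > 100000 nM in this assay, at which 1 of the 3 values shown sits. On the saturated chain carbon bound to an amide-type nitrogen in a ring, cyanosulfanyl in place of selenium gives an at least 15-fold higher number from compound 2 to compound 3 (1.19 log units; beyond the scatter), so the lower number of compound 2 does not carry over to this sulfur-bearing group, and both sulfur compounds now stand well away from the selenium compound. The nitrile itself adds little that can be read: cyano in place of hydrogen on a sulfur gives an at least 1.3-fold higher number from compound 1 to compound 3 (0.12 log units; that floor lies within the scatter), which fixes no direction beyond the scatter, though it does show that the nitrile on sulfur brings back none of the selenium step.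

The compounds shown leave open how far compound 3 lies past its limit, and whether a nitrile on selenium would keep the lower number of compound 2 or lose it as the nitrile on sulfur compound did. They also leave open whether the selenium step survives on a longer chain, or whether an amine or a carboxylic acid at the same carbon would be tolerated at all.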